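From 4-Nitrobenzyl to 2-Methylbenzyl in a Small Series

A few compounds are considered here, and "the series" means these few. Any claim that something is new, unique, unknown or untested is made for them only; others in the source may bear on it.

In a functional assay on BGC-823 cells (Homo sapiens) for antiproliferative activity, read by MTT assay, with a stated time of 24 h (on this read-out lower numbers stand for stronger inhibition and higher numbers for weaker inhibition), compound 1 `c1ccc(CSc2nnc(-c3ccc4c(c3)OCCO4)n2-c2ccccc2)cc1` gives 73400 nM, and compound 2 `O=[N+]([O-])c1ccc(CSc2nnc(-c3ccc4c(c3)OCCO4)n2-c2ccccc2)cc1` gives 48600 nM. These two numbers lie within the scatter of each other, so compound 2 cannot be ranked against compound 1. Compound 3 `Cc1ccccc1CSc1nnc(-c2ccc3c(c2)OCCO3)n1-c1ccccc1` has not yet been measured. It carries 2-methylphenyl in place of 4-nitrophenyl on a saturated chain carbon bound to a sulfur. Among the measured compounds shown here, only one measured step bears on this change, and it concerns the nitro group: a 1.5-fold lower number from compound 1 to compound 2 (0.18 log units; within the scatter). For the measured compounds named here, no measurement yet shows what the methyl group does, so this guidance is limited. Going by the values given here, with only that small step to go on, no change beyond the scatter is expected in this assay. The expected step is a 1.2-fold higher number from compound 2 to compound 3 (0.09 log units; within the scatter). For compound 3 the estimated value is 60000 nM, with an expected range of 25000 nM to 130000 nM.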

Compound 3, half-maximal inhibitory concentration: > 100000 nM
Compound 3 was reported as a limit; the forecaster's own chance of this, stated with the estimate: 10%; at least 1.6-fold (0.22 log units) between middle value and limit.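

Compound 3 is reported only as a limit: (the limit of > 100000 nM in this assay, at which 1 of the 3 values shown sits). Even so, the change to 2-methylphenyl on a saturated chain carbon bound to a sulfur gives an at least 2.0-fold higher number from compound 2 to compound 3 (0.31 log units; beyond the scatter) in this assay and is the first step in this small series to clear the scatter, so this position is not indifferent to the group it carries. Compound 3 still cannot be ranked against compound 1, since the methyl group gives only an at least 1.3-fold higher number from compound 1 to compound 3 (0.13 log units; that floor lies within the scatter) and that floor settles nothing.

The step from the nitro compound removes a nitro group and adds a methyl group at once, so the compounds shown cannot tell which of the two matters. Also open, going by these compounds, is how an amine or a carboxylic acid on the same ring would read in this assay, as all three numbers so far are high.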